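Naphthyl Amide Variant in a Cytotoxicity Series

The source may hold more compounds than are shown below. What is called first, only, known or untested is meant among the compounds shown, and "the series" means these compounds.

Compound 1 `CN1[C@@H]2c3[nH]c4ccccc4c3C[C@H]1[C@H](C#N)N1[C@@H](CN3C(=O)c4ccccc4C3=O)c3[nH]c4ccccc4c3C[C@@H]21` and compound 2 `CN1[C@@H]2c3[nH]c4ccccc4c3C[C@H]1[C@H](C#N)N1[C@@H](CNC(=O)c3ccc(F)cc3)c3[nH]c4ccccc4c3C[C@@H]21` share one core and differ only in the group carried on a saturated chain carbon. In a functional assay on HepG2 cells (Homo sapiens) for cytotoxicity, read by MTT assay, with a stated time of 72 h (a lower number here means a stronger inhibitor, a higher number a weaker inhibitor), compound 1 gives 20 nM, while compound 2 gives 210 nM. For the measured compounds named here, the single known step, an 11-fold higher number from compound 1 to compound 2 (1.02 log units; beyond the scatter), is large, and compound 2 therefore stands at the highest of the two numbers measured so far, with compound 1 as its only neighbour.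

Compound 3 `CN1[C@@H]2c3[nH]c4ccccc4c3C[C@H]1[C@H](C#N)N1[C@@H](CNC(=O)c3ccc4ccccc4c3)c3[nH]c4ccccc4c3C[C@@H]21` departs from compound 2 by naphthalen-2-yl in place of 4-fluorophenyl on a carbonyl carbon. Going by the values given here, no measured step exchanges one aromatic ring for another on this carbonyl carbon; the step of an 11-fold higher number from compound 1 to compound 2 (1.02 log units; beyond the scatter) concerns a different replacement at the same chain carbon and does not bear directly on the present change. Without such a guide, the step of a 1.6-fold lower number from compound 2 to compound 3 (0.21 log units; within the scatter) is expected to be modest and could fall on either side, with no confident move beyond the scatter. Compound 3 is estimated to give 130 nM in this assay, within an expected range from 35 nM to 500 nM.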

Compound 3, half-maximal inhibitory concentration: 1210 nM
Compound 3: the middle estimate sits 9.3-fold (0.97 log units) below what was measured, and the stated range ends below it.
By their numbers in this assay, from the lowest: compound 1; then compound 2; then compound 3.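

The exchange on this carbonyl carbon proves far from neutral in this assay: a 5.8-fold higher number from compound 2 to compound 3 (0.76 log units; beyond the scatter) shows that the aromatic group on the amide carbonyl matters in its own right, whereas the earlier step, an 11-fold higher number from compound 1 to compound 2 (1.02 log units; beyond the scatter), concerned only a different replacement at the chain carbon. The change from 4-fluorophenyl to naphthalen-2-yl removes the fluorine and adds a second six-membered aromatic ring in a single move, and it moves the number upward, so these two compounds give one direction for this one exchange and no more than that. No measurement at hand gives a reason for the size or direction of this step.

The compounds shown leave open whether the loss of the fluorine or the gain of the second ring carries the step, a question that a plain phenyl on the same carbonyl carbon would address. They also leave open how this position would respond to a non-aromatic group such as cyclohexyl, or to a ring containing nitrogen such as pyridin-3-yl.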